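This account rests on a few compounds, and the source may have more. Where it says the series, first, only, none or still open, it means among the compounds named here.

Working notes on the cap series of the tetrapeptide.

Compound 1 `CC(C)C[C@H](NC(=O)[C@H](C)NC(=O)c1ccccc1)C(=O)N[C@@H](CCCC[N+](C)(C)C)C(=O)N[C@@H](CO)C(N)=O` carries a benzoyl group on the alanine nitrogen; in an assay on isolated protein for displacement of a labelled ligand from Chromobox protein homolog 7 (Homo sapiens), read by fluorescence polarization, with a stated time of 15 min (on this read-out higher numbers stand for weaker inhibition and lower numbers for stronger inhibition), compound 1 gives 57000 nM. Compound 2 `CC(C)C[C@H](NC(=O)[C@H](C)NC(=O)OCc1ccccc1)C(=O)N[C@@H](CCCC[N+](C)(C)C)C(=O)N[C@@H](CO)C(N)=O` carries a benzyloxycarbonyl group at the same place; in this assay compound 2 gives 58000 nM. Only these two numbers exist so far, and the value of compound 2 lies within the usual scatter of that of compound 1: the step of a 1.0-fold higher number from compound 1 to compound 2 (0.01 log units; within the scatter) is flat.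

Compound 3 `COc1ccc(S(=O)(=O)N[C@@H](C)C(=O)N[C@@H](CC(C)C)C(=O)N[C@@H](CCCC[N+](C)(C)C)C(=O)N[C@@H](CO)C(N)=O)cc1` is the next member. It differs from compound 2 by (4-methoxyphenyl)sulfonyl in place of benzyloxycarbonyl on an amine nitrogen.

For the measured compounds named here, the only step that bears on this change is the one at the same position, a 1.0-fold higher number from compound 1 to compound 2 (0.01 log units; within the scatter), which swapped one aromatic cap on the alanine nitrogen for another and moved the number by nothing beyond the scatter. The change to compound 3 again keeps a single six-membered aromatic ring on that nitrogen and alters the linking group. On this basis the expected step of no change at the digits printed from compound 2 to compound 3 (within the scatter) is none beyond the scatter. Compound 3 is therefore estimated at 58000 nM in this assay, with a range of 25000 nM to 130000 nM.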

Compound 3, half-maximal inhibitory concentration: > 250000 nM
Compound 3 ended at the assay's limit (the forecaster's own chance of this, stated with the estimate: 15%); at least 4.3-fold (0.63 log units) between middle value and limit.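

Working from these three compounds, the cap on the alanine nitrogen is not indifferent to what links the aromatic ring to that nitrogen. In this assay compound 3 gives > 250000 nM, which is a limit of the assay and not a number. The (4-methoxyphenyl)sulfonyl cap gives an at least 4.3-fold higher number from compound 2 to compound 3 (0.63 log units; beyond the scatter) and, measured against the benzoyl cap, an at least 4.3-fold higher number from compound 1 to compound 3 (0.64 log units; beyond the scatter), so the flat step a 1.0-fold higher number from compound 1 to compound 2 (0.01 log units; within the scatter) holds for the two carbonyl-linked caps only, and the full size of the new steps cannot be read: the limit of > 250000 nM in this assay, at which 1 of the 3 values shown sits.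

Compound 3 differs from compound 2 in both the sulfonyl link and the methoxy group, and the compounds shown do not separate the two; a phenylsulfonyl cap and a (4-methoxyphenyl)carbonyl cap on the same nitrogen would each change only one of them. Also open, from the compounds shown here alone, is how a cap without an aromatic ring, such as acetyl, or the free amine on that nitrogen would compare with the benzoyl and benzyloxycarbonyl caps.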